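The source may report more compounds than this note shows. Statements on the series, on what has been measured and on what is new or still open speak of the compounds shown alone.

Measured compounds in a functional assay on MCF7 cells (Homo sapiens) for antiproliferative activity, read by sulforhodamine B assay, with a stated time of 48 h; on this read-out lower numbers stand for stronger inhibition and higher numbers for weaker inhibition:
Compound 1, `O=C1NCCN1c1ccc(S(=O)(=O)Nc2ccc3[nH]ccc3c2)cc1`, gives 170 nM.
Compound 2, `CC(C)(C)c1ccc(NS(=O)(=O)c2ccc(N3CCNC3=O)cc2)cc1`, gives > 1000 nM, which is a limit of the assay rather than a number.
Compound 3, `CC(C)(C)c1cc(NS(=O)(=O)c2ccc(N3CCNC3=O)cc2)cc(C(C)(C)C)c1`, gives > 1000 nM, likewise a limit of the assay.

Compound 2 thus stands at the limit of this assay, and it shares that place with one other value shown, as the limit of > 1000 nM in this assay, at which 2 of the 3 values shown sit, records. Only compound 1 returns a number in this assay. Among the measured compounds shown here, no pair of measured compounds differs in a single place, so no measured step is available to set a scale.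

Compound 4, `COc1ccc(NS(=O)(=O)c2ccc(N3CCNC3=O)cc2)cc1`, is not yet measured. It differs from compound 2 by methoxy in place of tert-butyl on an aromatic carbon. With compound 2 at a limit, the step from it can only be expected, not anchored; the expected step that the limit leaves unreadable from compound 2 to compound 4 is toward somewhat stronger inhibition, though its size is not clearly beyond the usual scatter. For compound 4 the estimate in this assay is 1200 nM, with a range from 350 nM to 5000 nM.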

Compound 4, half-maximal inhibitory concentration: > 1000 nM
Compound 4 ended at the assay's limit; the forecaster's own chance of this, stated with the estimate: 50%; the middle value lies beyond the limit too.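

No step can be read between compound 2 and compound 4, as each sits at a limit of the assay and neither gives a number: the limit of > 1000 nM in this assay, at which 3 of the 4 values shown sit.

The compounds shown leave open whether methoxy and tert-butyl differ at all in their effect on inhibition, as only compound 1 returns a number.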